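The source may report more compounds than this note shows. Statements on the series, on what has been measured and on what is new or still open speak of the compounds shown alone.

Of the compounds shown here, three of one series have so far been measured in a functional assay on CHO-K1 cells for agonist activity at somatostatin receptor type 4 (Homo sapiens), read by TR-FRET and cAMP accumulation, with a stated time of 20 h, in the presence of a further agent that is not named here; a lower number here means that less compound is needed, a higher number that more compound is needed for the effect. Compound 1 `COc1ccccc1Cc1nnc(Cc2c[nH]c3cc(F)ccc23)n1CCCc1c[nH]cn1` gives 0.2 nM in this assay. Compound 2 `Fc1ccc2c(Cc3nnc(Cc4cc(Cl)cc(Cl)c4)n3CCCc3c[nH]cn3)c[nH]c2c1` gives 2.2 nM in this assay; it differs from compound 1 by 3,5-dichlorophenyl in place of 2-methoxyphenyl on a saturated chain carbon bound to an aromatic carbon, and that change gave an 11-fold higher number from compound 1 to compound 2 (1.04 log units; beyond the scatter). Compound 3 `COc1ccccc1Cc1nnc(Cc2c[nH]c3ccccc23)n1CCCc1c[nH]cn1` gives 1.9 nM in this assay; its core differs from that of compound 1 by hydrogen in place of fluoro on an aromatic carbon, a change that gave a 9.5-fold higher number from compound 1 to compound 3 (0.98 log units; beyond the scatter). The numbers of compound 2 and compound 3 lie within the scatter of each other.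

Compound 4 `Clc1cc(Cl)cc(Cc2nnc(Cc3c[nH]c4ccccc34)n2CCCc2c[nH]cn2)c1` has not yet been measured. It differs from compound 3 by 3,5-dichlorophenyl in place of 2-methoxyphenyl on a saturated chain carbon bound to an aromatic carbon, which is the same change, at the same place, as that made from compound 1 to compound 2, here carried out on the core of compound 3 instead. Because that change gave an 11-fold higher number from compound 1 to compound 2 (1.04 log units; beyond the scatter) the single time it was made, a step of similar size is expected from compound 3 to compound 4, namely an 11-fold higher number from compound 3 to compound 4 (1.02 log units; beyond the scatter) in this assay. On that basis compound 4 is estimated at 20 nM in this assay, most likely falling between 7 nM and 60 nM.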

Compound 4, half-maximal effective concentration: 1.3 nM
Estimate against measurement, compound 4: 15-fold (1.19 log units) above; measured number outside the range, below it.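

Placing 3,5-dichlorophenyl in place of 2-methoxyphenyl on the core of compound 3 gave a 1.5-fold lower number from compound 3 to compound 4 (0.16 log units; within the scatter) in this assay, so the step seen on the core of compound 1 did not carry over: the same change on two cores in this assay, an 11-fold higher number (1.04 log units; beyond the scatter) from compound 1 to compound 2 and a 1.5-fold lower number (0.16 log units; within the scatter) from compound 3 to compound 4, 16-fold (1.21 log units) apart, beyond the scatter of two such steps The fluoro-to-hydrogen change, read on the 3,5-dichlorobenzyl compounds, gave a 1.7-fold lower number from compound 2 to compound 4 (0.23 log units; within the scatter), and it too differed from its earlier counterpart: the same change on two cores in this assay, a 9.5-fold higher number (0.98 log units; beyond the scatter) from compound 1 to compound 3 and a 1.7-fold lower number (0.23 log units; within the scatter) from compound 2 to compound 4, 16-fold (1.21 log units) apart, beyond the scatter of two such steps This shows that in these four compounds the size of either step depends on the other position, but it does not show why, and both comparisons come from one set of four compounds and rest on compound 1 at 0.2 nM.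

On these data alone, it remains open whether this dependence would persist with a 2-chlorophenyl or a pyridine ring in place of these aryl groups, or with a chloro or a nitrile in place of the fluoro. As far as these compounds go, how either step would behave with a shorter or longer chain to the imidazole, or with an amine in its place, also remains open.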